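Acylguanidine series: isopropoxy replacing furan-2-yl

The compounds below may be only part of what the source reports. "The series", "measured", "known", "first", "only" and "open" are said of these compounds alone.

Measured compounds:
compound 1, `Cc1cc(C2CCCCC2)c(S(C)(=O)=O)cc1C(=O)N=C(N)N` — 22 nM
compound 2, `Cc1cc(-c2ccco2)c(S(C)(=O)=O)cc1C(=O)N=C(N)N` — 16 nM

In a functional assay for inhibition of sodium/hydrogen exchanger (Oryctolagus cuniculus) (a lower number here means a stronger inhibitor, a higher number a weaker inhibitor), compound 2 gives 16 nM, and compound 1 gives 22 nM. Going by the values given here, the one measured step, a 1.4-fold lower number from compound 1 to compound 2 (0.14 log units; within the scatter), is within the scatter, so the two compounds cannot be told apart on these numbers.

Compound 3, `Cc1cc(OC(C)C)c(S(C)(=O)=O)cc1C(=O)N=C(N)N`, is not yet measured. Its change from compound 2 is isopropoxy in place of furan-2-yl on an aromatic carbon. Among the compounds with values here, no measured step covers an alkoxy group at this position; the only comparison available, a 1.4-fold lower number from compound 1 to compound 2 (0.14 log units; within the scatter), concerns a ring in place of a ring and shifted the number within the scatter. On this basis the step of a 1.6-fold higher number from compound 2 to compound 3 (0.19 log units; within the scatter) is expected to be small and its direction cannot be set from the data. Compound 3 is therefore estimated at 25 nM in this assay, with a range from 8 nM to 80 nM.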

Compound 3, half-maximal inhibitory concentration: 19 nM
For compound 3 the middle estimate is 1.3-fold (0.12 log units) above the measured one; measured number inside the range.
By their numbers in this assay, from the lowest: compounds 2, 3 and 1 (each within the scatter of the next).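

With an open-chain group at the position ortho to the methylsulfonyl group, this assay shows a 1.2-fold higher number from compound 2 to compound 3 (0.07 log units; within the scatter) and also a 1.2-fold lower number from compound 1 to compound 3 (0.06 log units; within the scatter) in the comparison with the cyclohexyl compound. Isopropoxy, with no ring, therefore cannot be told apart from either furan-2-yl or cyclohexyl on these numbers. Going by these compounds alone, the earlier pair compared only one ring with another, whereas compound 1, compound 2 and compound 3 together show that a ring at this position is not required to keep the number in this range. Nothing measured here explains why these three groups read alike. As far as these compounds go, whether an amine, a carboxylic acid or a longer alkoxy chain at this position would stay in the same range remains open. So does the reading with a plain hydrogen there, which would show what any of these groups contributes.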